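The source may report more compounds than this note shows. Statements on the series, on what has been measured and on what is new or still open speak of the compounds shown alone.

Measured in a functional assay on HepG2 cells (Homo sapiens) for inhibition, read by MTT assay, with a stated time of 24 h; a lower number here means a stronger inhibitor of growth, a higher number a weaker inhibitor of growth:
- compound 1 `COc1cccc(C(=O)n2c(-c3cn(C)c4ccccc34)nc3ccccc32)c1`: 13600 nM
- compound 2 `COc1cc(C(=O)n2c(-c3cn(C)c4ccccc34)nc3ccccc32)cc(OC)c1OC`: 4300 nM

Compound 1 holds the higher number of the pair, which makes it the weaker inhibitor of growth, and the gap to compound 2 lies beyond the scatter. Compound 3 `Cn1cc(-c2nc3ccccc3n2C(=O)c2ccccc2Br)c2ccccc21` carries 2-bromophenyl in place of 3-methoxyphenyl on a carbonyl carbon. Within the data shown here, no measured pair shows this change, so only a small downward step in this assay, within the scatter, is expected. The expected move is a 1.7-fold lower number from compound 1 to compound 3 (0.23 log units; within the scatter). For compound 3 the estimated value is 8000 nM, with an expected range from 2500 nM to 25000 nM.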

Compound 3, concentration for 50% growth inhibition: 68200 nM
The estimate for compound 3 lay 8.5-fold (0.93 log units) below the measured number; measured number outside the range, above it.
By their numbers in this assay, from the lowest: compound 2; then compound 1; then compound 3.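

In this assay, the group on the carbonyl carbon proved able to shift growth inhibition, with 2-bromophenyl in place of 3-methoxyphenyl giving a weaker inhibitor (a 5.0-fold higher number from compound 1 to compound 3 (0.70 log units; beyond the scatter)). This is the first single-place change shown at this position, and its step lies beyond the scatter. Nothing available explains the loss. The compounds shown leave open whether the bromine itself or its place on the ring carries the step. They also leave open how a phenyl bearing an amine or a carboxylic acid would read on this carbonyl carbon.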